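A Methyl Group Added to Compound 2

This account rests on a few compounds, and the source may have more. Where it says the series, first, only, none or still open, it means among the compounds named here.

In a functional assay on the whole organism for agonist activity, with Mus musculus as the target (on this read-out lower numbers stand for an effect already at smaller amounts and higher numbers for an effect only at larger amounts of compound), compound 1 `COC(=O)N(C)C(C)C#CCN1CCCC1` gives 9.7 mg/kg, and compound 2 `CCOC(=O)N(C)CC#CCN1CCCC1` gives 66 mg/kg, the higher of the two numbers, with a gap beyond the usual scatter. Compound 3 `CCOC(=O)N(C)C(C)C#CCN1CCCC1` arises from compound 2 through a single change, methyl in place of hydrogen on a saturated chain carbon bound to an amide-type nitrogen and a triple-bonded carbon. Among the compounds with values here, no measured pair isolates this change, so any expectation remains tentative. Within the data shown here, the only measured compound with a methyl at that place is compound 1, at 9.7 mg/kg, although it also differs from compound 2 elsewhere. In this assay a moderate step toward a lower number, beyond the scatter, is therefore expected: a 3.3-fold lower number from compound 2 to compound 3 (0.52 log units; beyond the scatter). For compound 3 the estimated value is 20 mg/kg, with an expected range from 7 mg/kg to 60 mg/kg.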

Compound 3, dose for half-maximal effect: > 100 mg/kg
Compound 3 gave a limit, no number; the forecaster's own chance of this, stated with the estimate: 3%; middle value at least 5.0-fold (0.69 log units) from the limit.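

In this assay, methyl in place of hydrogen at this chain carbon gives an at least 1.5-fold higher number from compound 2 to compound 3 (0.18 log units; that floor lies within the scatter), so with the ethyl ester kept, the methyl does not bring a lower number, although the size of any rise remains unsettled. The change on the other side of the molecule, methyl in place of hydrogen on a saturated chain carbon bound to an oxygen next to a carbonyl group, gives an at least 10-fold higher number from compound 1 to compound 3 (1.01 log units; beyond the scatter), which shows that with the chain methyl present this second site makes a large difference. Compound 3 is read only as a limit of the assay, not as a number: the limit of > 100 mg/kg in this assay, at which 1 of the 3 values shown sits.

As far as these compounds go, how far compound 3 lies past that limit stays open. It is also unknown whether an ethyl group at the chain carbon, or a propyl group on the oxygen, would continue this trend.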